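Swapping a Halogen in a Series of Cell-Growth Inhibitors

The compounds below may be only part of what the source reports. "The series", "measured", "known", "first", "only" and "open" are said of these compounds alone.

Compound 1 `Clc1cccc(Nc2ncnc3ccc(NCc4ccc5c(c4)OCCCCO5)cc23)c1` was tested in a functional assay on A-431 cells (Homo sapiens) for antiproliferative activity, read by WST assay, with a stated time of 48 h (a lower number here means a stronger inhibitor, a higher number a weaker inhibitor), where compound 1 gives 13.3 ug/mL. Among the three compounds with numbers, this is the second highest. Compound 2 `Clc1cccc(Nc2ncnc3ccc(NCc4ccc5c(c4)OCCCO5)cc23)c1` gives 2.59 ug/mL in this assay, a lower number than compound 1 by a margin beyond the scatter, while compound 3 `O=C(Nc1ccc2ncnc(Nc3cccc(Br)c3)c2c1)C1COc2ccccc2O1` gives 42.9 ug/mL, higher than compound 1 by a margin also beyond the scatter. Compound 4 `Brc1cccc(Nc2ncnc3ccc(NCc4ccc5c(c4)OCCCCO5)cc23)c1` has not yet been measured. It differs from compound 1 in one place: bromo in place of chloro on an aromatic carbon. For the measured compounds named here, no measured pair isolates this exchange, so compound 1 is the only anchor. The writer expects the step from compound 1 to compound 4 to be small, within the scatter, estimated at a 1.2-fold lower number from compound 1 to compound 4 (0.08 log units; within the scatter). Compound 4 is expected to give about 11 ug/mL in this assay, within 4 ug/mL to 30 ug/mL.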

Compound 4, half-maximal inhibitory concentration: 15 ug/mL
For compound 4 the middle estimate is 1.4-fold (0.13 log units) below the measured one; the range from low to high includes it.
By their numbers in this assay, from the lowest: compound 2; then compounds 1 and 4 (each within the scatter of the next); then compound 3.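

Bromo in place of chloro on this aromatic carbon gives a 1.1-fold higher number from compound 1 to compound 4 (0.05 log units; within the scatter) in this assay and so provides the first direct reading of this exchange, which no earlier pair isolated. At this position, the 3-chlorophenyl and 3-bromophenyl compounds cannot be told apart in this assay. Nothing at hand explains this result. On these data alone, it remains open whether a group other than a halogen at this place, such as an amine, a methoxy group or a carboxylic acid, would leave the number as unchanged. As far as these compounds go, whether bromo in place of chloro would read the same on compound 2 also remains open.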